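The source may report more compounds than this note shows. Statements on the series, on what has been measured and on what is new or still open speak of the compounds shown alone.

Of the compounds shown here, three sharing one core have been tested in a functional assay on BJAB cells (Homo sapiens) for antiproliferative activity, with a stated time of 4 days; on this read-out higher numbers stand for an effect only at larger amounts of compound and lower numbers for an effect already at smaller amounts. Compound 1 `Cc1cc(C)cc(-c2c(C)nn(-c3nc(-c4ccc(Cl)c(Cl)c4)c(SC(C)C)s3)c2C(=O)O)c1` gives 2700 nM, compound 2 `Cc1cc(Cl)cc(-c2c(C)nn(-c3nc(-c4ccc(Cl)c(Cl)c4)c(SC(C)C)s3)c2C(=O)O)c1` gives 663 nM, and compound 3 `Cc1nn(-c2nc(-c3ccc(Cl)c(Cl)c3)c(SC(C)C)s2)c(C(=O)O)c1-c1cncc(C#N)c1` gives 20000 nM, the highest number of the three. The steps show a 4.1-fold lower number from compound 1 to compound 2 (0.61 log units; beyond the scatter), a 7.4-fold higher number from compound 1 to compound 3 (0.87 log units; beyond the scatter) and a 30-fold higher number from compound 2 to compound 3 (1.48 log units; beyond the scatter). Compound 4 `Cc1cc(C#N)cc(-c2c(C)nn(-c3nc(-c4ccc(Cl)c(Cl)c4)c(SC(C)C)s3)c2C(=O)O)c1` differs from compound 3 by 3-cyano-5-methylphenyl in place of 5-cyanopyridin-3-yl on an aromatic carbon. As far as these compounds go, since both earlier moves onto the cyanopyridine raised the number, returning to a substituted benzene ring is expected to lower it; the methyl-to-chloro step from compound 1 to compound 2 hints that a small electron-poor substituent is tolerated, though cyano itself is untested. Compound 4 is therefore expected at 1500 nM, between 400 nM and 6000 nM, meaning a 13-fold lower number from compound 3 to compound 4 (1.12 log units; beyond the scatter).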

Compound 4, half-maximal effective concentration: 4800 nM
Beside the measured number, compound 4's estimate is 3.2-fold (0.51 log units) below it; measured number inside the range.
By their numbers in this assay, from the lowest: compound 2; then compounds 1 and 4 (each within the scatter of the next); then compound 3.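

With a nitrile on both rings, 3-cyano-5-methylphenyl in place of 5-cyanopyridin-3-yl gives a 4.2-fold lower number from compound 3 to compound 4 (0.62 log units; beyond the scatter), so the nitrile alone does not account for the high number of compound 3. On the benzene ring, cyano in place of chloro gives a 7.2-fold higher number from compound 2 to compound 4 (0.86 log units; beyond the scatter), while cyano in place of methyl gives a 1.8-fold higher number from compound 1 to compound 4 (0.25 log units; within the scatter), which sets chloro apart from both other groups. No evidence on the cause of these shifts is at hand. Still open, as far as these compounds go, is whether the step to compound 4 comes from losing the ring nitrogen or from gaining the methyl. Also open, from the compounds shown here alone, is how a trifluoromethyl or methoxy group would compare with chloro on this ring.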